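Aryloxy variation on a diaminoquinoxaline core for K562 growth inhibition

The compounds below may be only part of what the source reports. "The series", "measured", "known", "first", "only" and "open" are said of these compounds alone.

Compound 1 `Nc1cc(N)c2nc(-c3ccccc3)c(Oc3ccc(Cl)c(Cl)c3)nc2c1` and compound 2 `COc1ccc(Sc2nc3cc(N)cc(N)c3nc2-c2ccccc2)cc1` share one core and differ only in the group carried on an aromatic carbon of it. In a functional assay on K562 cells (Homo sapiens) for inhibition, read by sulforhodamine B assay, with a stated time of 48 h (a lower number here means a stronger inhibitor of growth, a higher number a weaker inhibitor of growth), compound 1 gives < 100000 nM, which is a limit of the assay rather than a number. In this assay compound 2 likewise gives < 100000 nM, again a limit and not a number. Going by the values given here, the step that the two limits leave unreadable from compound 1 to compound 2 therefore cannot be read, and the two values show only that both compounds sit at the limit of < 100000 nM in this assay, at which 2 of the 2 values shown sit.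

Compound 3 `Nc1cc(N)c2nc(-c3ccccc3)c(Oc3ccc(F)cc3)nc2c1` is the next member. It differs from compound 2 by 4-fluorophenoxy in place of (4-methoxyphenyl)sulfanyl on an aromatic carbon. Among the compounds with values here, only the unreadable step from compound 1 to compound 2 bears on this kind of exchange, so no measured step gives a size or a direction for the change in this assay; the expectation rests solely on the fact that both known compounds sit at the same limit. Compound 3 is therefore expected to show a step that the limit leaves unreadable from compound 2 to compound 3, and its estimated total growth inhibition concentration is 40000 nM, with a range from 5000 nM to 100000 nM.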

Compound 3, concentration for total growth inhibition: < 100000 nM
Compound 3 gave a limit, no number; the forecaster's own chance of this, stated with the estimate: 70%; the middle value is on the limit's open side.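

In this assay compound 3 gives < 100000 nM, again a limit of the assay and not a number. Its steps from compound 1 and compound 2 therefore cannot be read, and the three compounds share one limit: the limit of < 100000 nM in this assay, at which 3 of the 3 values shown sit.

The compounds shown leave open whether, and by how much, 4-fluorophenoxy, 3,4-dichlorophenoxy and (4-methoxyphenyl)sulfanyl differ in this assay.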